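From (oxiran-2-yl)methoxy to bromo on an aromatic carbon

The compounds below may be only part of what the source reports. "The series", "measured", "known", "first", "only" and "open" are said of these compounds alone.

Among the compounds with values here, in a functional assay on DU-145 cells (Homo sapiens) for cytotoxicity (a lower number here means a stronger inhibitor of growth, a higher number a weaker inhibitor of growth), compound 2 (`CSc1ccc(C2=C(c3ccc(OCC4CO4)cc3)C(=O)N3CCCC3C2)cc1`) gives 500 nM and stands within the scatter of its only measured neighbour, compound 1 (`COc1ccc(C2=C(c3ccc(SC)cc3)CC3CCCN3C2=O)cc1`), which gives 900 nM in that test. Compound 3 (`CSc1ccc(C2=C(c3ccc(Br)cc3)C(=O)N3CCCC3C2)cc1`) carries bromo in place of (oxiran-2-yl)methoxy on an aromatic carbon para to a large group. Within the data shown here, one measured step bears on this substituent: a 1.8-fold lower number from compound 1 to compound 2 (0.26 log units; within the scatter) stays within the scatter, as the oxygen-bound chain is altered. Among the measured compounds shown here, no measured compound carries bromo, so that step is only a weak guide and the direction remains uncertain. The expected change is a 1.6-fold higher number from compound 2 to compound 3 (0.20 log units; within the scatter) and no step beyond the scatter is expected. For compound 3 the estimated value in this assay is 800 nM with an expected range from 300 nM to 2500 nM around that estimate.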

Compound 3, concentration for 50% growth inhibition: 9000 nM
Compound 3: the middle estimate sits 11-fold (1.05 log units) below what was measured; measured number outside the range, above it.
By their numbers in this assay, from the lowest: compounds 2 and 1 (each within the scatter of the next); then compound 3.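

In this assay this aromatic carbon turns out not to be indifferent to its substituent, which compound 1 and compound 2 alone could not show: bromo in place of (oxiran-2-yl)methoxy gives an 18-fold higher number from compound 2 to compound 3 (1.26 log units; beyond the scatter) and bromo in place of methoxy gives a 10-fold higher number from compound 1 to compound 3 (1.00 log units; beyond the scatter) in the same test. The two groups bound through oxygen remain within the scatter of each other, so among these three compounds only bromo stands apart, with compound 3 the weakest inhibitor of growth. Nothing shown here gives a measured reason for this difference.

From the compounds shown here alone, it remains open whether the weaker inhibition belongs to bromo itself or to any group lacking that oxygen. A hydroxy group, an amine or chloro on the same aromatic carbon would help separate these possibilities.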